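A few compounds are considered here, and "the series" means these few. Any claim that something is new, unique, unknown or untested is made for them only; others in the source may bear on it.

Compound 2 `O=C(CCCc1ccccc1)Nc1nc2ccccc2c(=O)s1` is the starting point. In an assay on CHO cells for displacement of a labelled ligand from adenosine receptor A2b (Homo sapiens), read by scintillation counting, with a stated time of 75 min (on this read-out lower numbers stand for stronger inhibition and higher numbers for weaker inhibition), compound 2 gives > 1000 nM, which is a limit of the assay rather than a number. Compound 1 `O=C(CCCc1ccccc1)Nc1nc2ccc(Cl)cc2c(=O)s1` differs from compound 2 only by a chloro substituent on the shared core. In this assay compound 1 gives > 1000 nM, again a limit. The step that the two limits leave unreadable from compound 1 to compound 2 cannot be sized because of the limit of > 1000 nM in this assay, at which 2 of the 2 values shown sit. Compound 3 `O=C(CCCc1ccccc1)Nc1nc2ccc(Br)cc2c(=O)s1` differs from compound 2 by bromo in place of hydrogen on an aromatic carbon. Within the data shown here, no measured step bears readably on this change, so no direction beyond the scatter is expected. Compound 3 is expected at 3000 nM (range 800 nM to 20000 nM). The step that the limit leaves unreadable from compound 2 to compound 3 is an estimate only.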

Compound 3, inhibition constant: > 1000 nM
Compound 3: a limit, no number; the forecaster's own chance of this, stated with the estimate: 80%; the middle value is on the limit's open side.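

Among these compounds, compound 3 also stands at a limit, so no step among compound 1, compound 2 and compound 3 can be read: the limit of > 1000 nM in this assay, at which 3 of the 3 values shown sit. What the compounds shown leave open is whether chloro or bromo in place of hydrogen changes the result in this assay at all.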